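The source may hold more compounds than are shown below. What is called first, only, known or untested is meant among the compounds shown, and "the series" means these compounds.

Measured compounds:
Compound 1 `CN1CCC[C@H]1COc1cncc(O)c1` gives 235 nM in an assay on HEK293 cells for displacement of a labelled ligand from Neuronal acetylcholine receptor; alpha3/beta4 (Homo sapiens), read by scintillation counting; on this read-out higher numbers stand for weaker inhibition and lower numbers for stronger inhibition.
Compound 2 `Oc1cncc(OC[C@@H]2CCCN2)c1` gives 100 nM in this assay.
Compound 3 `COc1ccccc1OC[C@@H]1CCCN1` gives 3600 nM in this assay.

Compound 3 stands highest of the three; the difference between its core and the core of compound 2 is not broken down here. Compound 4 `COc1ccccc1OC[C@@H]1CCCN1C` is not yet measured. It differs from compound 3 by methyl in place of hydrogen on an amine nitrogen in a ring. The same kind of change separates compound 2 from compound 1, (methyl in place of hydrogen on an amine nitrogen in a ring); the place differs only in that the ring atom bears a large group in one case and a group of 9 heavy atoms in the other. That earlier step gave a 2.4-fold higher number from compound 2 to compound 1 (0.37 log units; beyond the scatter). For the measured compounds named here, a step of similar size is expected from compound 3 to compound 4, a 2.4-fold higher number from compound 3 to compound 4 (0.38 log units; beyond the scatter), because the single comparable pair shows a 2.4-fold higher number from compound 2 to compound 1 (0.37 log units; beyond the scatter). Compound 4 is therefore estimated at 8600 nM, with a likely range from 3600 nM to 20000 nM.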

Compound 4, inhibition constant: 749 nM
Compound 4: middle estimate off by 11-fold (1.06 log units), on the high side; the measured number lies below the stated range.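

In this assay, methyl in place of hydrogen on an amine nitrogen in a ring now gives a 4.8-fold lower number from compound 3 to compound 4 (0.68 log units; beyond the scatter). Set beside the earlier step, the same change does not carry over from one core to the other, even in direction: the same change on two cores in this assay, a 2.4-fold higher number (0.37 log units; beyond the scatter) from compound 2 to compound 1 and a 4.8-fold lower number (0.68 log units; beyond the scatter) from compound 3 to compound 4, 11-fold (1.05 log units) apart, beyond the scatter of two such steps. So the result of this methyl in this series cannot be read from one core and applied to another, but these two pairs do not show which difference between the cores matters, or what a further core would do.

The compounds shown leave open how an ethyl group or a longer chain on the same amine nitrogen would behave on either core. For the compounds shown here, they also leave open whether such groups would follow the step seen on compound 1 or the one seen on compound 4.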